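Series notes: benzyl to cyclohexyl on compound 1

The source may hold more compounds than are shown below. What is called first, only, known or untested is meant among the compounds shown, and "the series" means these compounds.

Measured in a functional assay on DU-145 cells (Homo sapiens) for cytotoxicity, read by MTT assay, with a stated time of 48 h; on this read-out lower numbers stand for stronger inhibition and higher numbers for weaker inhibition:
compound 1 `O=C(NCc1ccccc1)N(Cc1ccccn1)n1cnnc1`, 21200 nM
compound 2 `COc1ccc(CN(C(=O)Nc2ccc(C#N)cc2)n2cnnc2)cc1OC`, 24100 nM
compound 3 `Cc1ccsc1CN(C(=O)Nc1cccc(C#N)c1)n1cnnc1`, 31000 nM

Compound 1 gives the lowest of the three numbers, but its gaps to compound 2 and to compound 3 both fall within the scatter, so the three compounds are not separated on this assay. Going by the values given here, no step between two measured compounds that differ in one place is available in this set. On these data alone, compound 4 `O=C(NC1CCCCC1)N(Cc1ccccn1)n1cnnc1` is untested; it differs from compound 1 by cyclohexyl in place of benzyl on an amide-type nitrogen. Without any comparable measured step, the expected 1.2-fold higher number from compound 1 to compound 4 (0.07 log units; within the scatter) is a change no larger than the scatter, in either direction. Compound 4 is therefore estimated at 25000 nM, with a range from 9000 nM to 70000 nM.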

Compound 4, half-maximal inhibitory concentration: > 50000 nM
Compound 4 was reported as a limit; the forecaster's own chance of this, stated with the estimate: 25%; at least 2.0-fold (0.30 log units) between middle value and limit.
By their numbers in this assay, from the lowest: compounds 1, 2 and 3 (each within the scatter of the next). At a limit, above all of these: compound 4.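

In this assay, going by these compounds alone, cyclohexyl in place of benzyl on an amide-type nitrogen gives an at least 2.3-fold higher number from compound 1 to compound 4 (0.37 log units; beyond the scatter) and provides the first single-change step, showing that this position is sensitive to the change from an aromatic to a non-aromatic ring. Compound 4 gives > 50000 nM, which is a limit, so the step has a floor but no measured size: the limit of > 50000 nM in this assay, at which 1 of the 4 values shown sits.

On these data alone, whether other groups at this position keep the value of compound 1 remains open. A phenyl ring, a phenethyl chain or an open hexyl chain would test this.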